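Swapping One Aromatic Group and Estimating Cell Tolerance

A few compounds are considered here, and "the series" means these few. Any claim that something is new, unique, unknown or untested is made for them only; others in the source may bear on it.

Compound 1 `Cc1nc(C(NC(=O)C(=O)Nc2ccc(F)cc2)C2CCCCN2)sc1CCO` gives 109000 nM
Compound 2 `Cc1nc(C(NC(=O)C(=O)Nc2ccc(F)cc2F)C2CCCCN2)sc1CCO` gives > 105000 nM

In an ADME assay on MT2 cells (Homo sapiens) for cytotoxicity, read by XTT assay, with a stated time of 4 days (a higher number here means that more compound is tolerated, a lower number that less compound is tolerated), compound 2 gives > 105000 nM as a limit of the assay and not a number. Its place is marked only by the limit of > 105000 nM in this assay, at which 1 of the 2 values shown sits, and by nothing finer. Compound 1 gives 109000 nM as a true measured number. Among the compounds with values here, the one measured step that bears on the change is a step that the limit leaves unreadable from compound 1 to compound 2 with fluoro in place of hydrogen on an aromatic carbon, so no size can be carried over from it.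

Compound 3 `Cc1nc(C(NC(=O)C(=O)Nc2ccc(F)c(Cl)c2)C2CCCCN2)sc1CCO` has 3-chloro-4-fluorophenyl in place of 2,4-difluorophenyl on an amide-type nitrogen, and 3-chloro-4-fluorophenyl in place of 2,4-difluorophenyl on an amide-type nitrogen sets out the count. With no readable step to lean on, no shift beyond the usual scatter is expected in this assay in either direction. Within the data shown here, the estimate rests on compound 1 at 109000 nM as the only true number available. The expected change is an at least 1.1-fold lower number from compound 2 to compound 3 (0.06 log units; that floor lies within the scatter) and no more. For compound 3 the estimate is 90000 nM with an expected range from 40000 nM to 170000 nM in this measurement.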

Compound 3, half-maximal cytotoxic concentration: 94700 nM
Compound 3: middle estimate off by 1.1-fold (0.02 log units), on the low side; the measured number falls inside the stated range.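

Compound 3 adds a true number at this place on the aromatic ring, so a halogen swap there can now be sized. In this assay, a chloro added to the aromatic ring gives a 1.2-fold lower number from compound 1 to compound 3 (0.06 log units; within the scatter), so compound 1 and compound 3 cannot be told apart in cell tolerance. Set against the previous compound, 3-chloro-4-fluorophenyl in place of 2,4-difluorophenyl on an amide-type nitrogen reads as an at least 1.1-fold lower number from compound 2 to compound 3 (0.04 log units; that floor lies within the scatter), a floor that shows no shift beyond the scatter and puts no upper bound on the step. Compound 2 carries a limit of the assay and not a number, so its step from compound 1 cannot be read: the limit of > 105000 nM in this assay, at which 1 of the 3 values shown sits.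

As far as these compounds go, all three compounds carry halogens on this phenyl ring, so it remains open whether a methoxy group, a nitrile or an amine on the ring, or a ring with no halogen at all, would stay within the scatter in this assay. From the compounds shown here alone, it is also open whether a larger halogen such as bromine would behave as chloro does here.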